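Extending the ether chain with a pyridine ring

The source may hold more compounds than are shown below. What is called first, only, known or untested is meant among the compounds shown, and "the series" means these compounds.

Of the compounds shown here, two have been measured so far. Compound 1 `CCc1sc(CCc2cc(OC3CCCC3)cc(NCc3cc(Cl)cc(NC(=O)OC(C)C)c3)n2)nc1C` gives 11 nM in an assay on cells for binding affinity to Neuropeptide Y receptor type 1 (Homo sapiens) (on this read-out lower numbers stand for stronger inhibition and higher numbers for weaker inhibition), and compound 2 `CCc1sc(CCc2cc(OCCc3ccccc3)cc(NCc3cc(Cl)cc(NC(=O)OC(C)C)c3)n2)nc1C` gives 30 nM. For the measured compounds named here, compound 2 therefore stands at the higher, weaker end of the two numbers, and the one measured step, a 2.7-fold higher number from compound 1 to compound 2 (0.44 log units; beyond the scatter), shows that replacing the cyclopentyl with a phenethyl on the ether oxygen cost a modest amount of affinity.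

Compound 3 `CCc1sc(CCc2cc(OCCCc3cccnc3)cc(NCc3cc(Cl)cc(NC(=O)OC(C)C)c3)n2)nc1C` is not yet measured. It differs from compound 2 by (pyridin-3-yl)methyl in place of phenyl on a saturated chain carbon, two bonds along the chain from an oxygen on an aromatic ring; read one bond further out, this is phenethyloxy becoming 3-(pyridin-3-yl)propoxy, so the chain grows by one atom and the ring now carries one hetero atom and one hydrogen-bond acceptor.

Going by the values given here, no measured step touches this exact change, since the only step known alters the group on the oxygen in a different way. The expectation for compound 3 is therefore a number close to that of compound 2, with a wide range, and the step of a 1.3-fold higher number from compound 2 to compound 3 (0.12 log units; within the scatter) is expected to stay within or only slightly beyond the scatter. Compound 3 is estimated at 40 nM, between 12 nM and 130 nM.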

Compound 3, half-maximal inhibitory concentration: 6.5 nM
Estimate against measurement, compound 3: 6.2-fold (0.79 log units) above; measured number below the stated range.
By their numbers in this assay, from the lowest: compounds 3 and 1 (each within the scatter of the next); then compound 2.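

In this assay, replacing phenethyl with 3-(pyridin-3-yl)propyl on the ether oxygen gives a 4.6-fold lower number from compound 2 to compound 3 (0.66 log units; beyond the scatter), so this position accepts a larger group than phenethyl and the number can improve there, which the first step, from cyclopentyl to phenethyl, gave no hint of. The comparison with the cyclopentyl ether gives a 1.7-fold lower number from compound 1 to compound 3 (0.23 log units; within the scatter) and, being within the scatter, shows that a chain ending in an aromatic ring can do as well here as the compact ring of compound 1. Nothing available explains why the number falls, and this single step changes the chain length and the ring together, so their contributions cannot be separated.

A 3-phenylpropyl group on the same oxygen would show how much of the change belongs to the longer chain alone and how much to the ring nitrogen. The pyridin-2-yl and pyridin-4-yl versions of the chain, and a still longer chain ending in pyridin-3-yl, would then show how closely the result depends on the ring nitrogen's placement and on chain length.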